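From 4-nitrophenyl to 3-nitrophenyl

A few compounds are considered here, and "the series" means these few. Any claim that something is new, unique, unknown or untested is made for them only; others in the source may bear on it.

Within the data shown here, in a functional assay on KB cells (Homo sapiens) for inhibition (on this read-out lower numbers stand for stronger inhibition and higher numbers for weaker inhibition), compound 1 `COc1ccc(CSc2nc3cc(Cl)c(Cl)cc3n2C2O[C@H](CO)[C@@H](O)[C@H]2O)cc1` gives 41000 nM and compound 2 `O=[N+]([O-])c1ccc(CSc2nc3cc(Cl)c(Cl)cc3n2C2O[C@H](CO)[C@@H](O)[C@H]2O)cc1` gives 30000 nM, so compound 2 stands level with the only other number available. That one measured step, a 1.4-fold lower number from compound 1 to compound 2 (0.14 log units; within the scatter), put nitro in place of methoxy. Compound 3 `O=[N+]([O-])c1cccc(CSc2nc3cc(Cl)c(Cl)cc3n2C2O[C@H](CO)[C@@H](O)[C@H]2O)c1` keeps the atoms of compound 2 but joins them differently: 3-nitrophenyl in place of 4-nitrophenyl on a saturated chain carbon bound to a sulfur. Among the measured compounds shown here, no measured step tests this kind of change, and the nitro for methoxy step gives no sign of a real shift, so none beyond the scatter is expected. The expected step is no change at the digits printed from compound 2 to compound 3 (within the scatter). Compound 3 is estimated at 30000 nM, within a range of 12000 nM to 75000 nM.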

Compound 3, half-maximal inhibitory concentration: 25000 nM
Compound 3: middle estimate off by 1.2-fold (0.08 log units), on the high side; measured number inside the range.
By their numbers in this assay, from the lowest: compounds 3, 2 and 1 (each within the scatter of the next).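

Among these compounds, putting 3-nitrophenyl in place of 4-nitrophenyl on a saturated chain carbon bound to a sulfur gives a 1.2-fold lower number from compound 2 to compound 3 (0.08 log units; within the scatter) in this assay and is the first test of where the nitro sits on this ring. Replacing 4-methoxyphenyl with 3-nitrophenyl at the same place gives a 1.6-fold lower number from compound 1 to compound 3 (0.21 log units; within the scatter) so all three aromatic groups read alike here. No independent measurement bears on this result.

Still open, on these data alone, is whether an amine or a carboxylic acid on this ring, or a longer chain in place of 3-nitrobenzyl, would move the number beyond the scatter.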